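Thiourea-to-urea swap on a second aromatic core

A few compounds are considered here, and "the series" means these few. Any claim that something is new, unique, unknown or untested is made for them only; others in the source may bear on it.

Measured compounds in a functional assay on MKN-74 cells (Homo sapiens) for antiproliferative activity, with a stated time of 24 h; on this read-out higher numbers stand for weaker inhibition and lower numbers for stronger inhibition:
Compound 1, `NC(=O)c1c(NC(=O)c2ccc(C(F)(F)F)cc2)sc2c1CCN(C(=S)Nc1ccccc1Cl)C2`, gives 16400 nM.
Compound 2, `NC(=O)c1c(NC(=O)c2ccc(C(F)(F)F)cc2)sc2c1CCN(C(=O)Nc1ccccc1Cl)C2`, gives 43900 nM.
Compound 3, `Cc1ccc(C(=O)Nc2sc3c(c2C(N)=O)CCN(C(=S)Nc2ccccc2Cl)C3)cc1`, gives 11300 nM.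

Compound 4, `Cc1ccc(C(=O)Nc2sc3c(c2C(N)=O)CCN(C(=O)Nc2ccccc2Cl)C3)cc1`, is not yet measured. It differs from compound 3 by a group of 10 heavy atoms (7 carbon, 1 nitrogen, 1 oxygen, 1 chlorine; one six-membered aromatic ring of carbon only) in place of a group of 10 heavy atoms (7 carbon, 1 nitrogen, 1 sulfur, 1 chlorine; one six-membered aromatic ring of carbon only), on an amine nitrogen in a ring. The same change has been made once already, from compound 1 to compound 2: a group of 10 heavy atoms (7 carbon, 1 nitrogen, 1 oxygen, 1 chlorine; one six-membered aromatic ring of carbon only) in place of a group of 10 heavy atoms (7 carbon, 1 nitrogen, 1 sulfur, 1 chlorine; one six-membered aromatic ring of carbon only), on an amine nitrogen in a ring, which brought a 2.7-fold higher number from compound 1 to compound 2 (0.43 log units; beyond the scatter). The two cores differ by methyl in place of trifluoromethyl on an aromatic carbon, a step of a 1.5-fold lower number from compound 1 to compound 3 (0.16 log units; within the scatter). Because a 2.7-fold higher number from compound 1 to compound 2 (0.43 log units; beyond the scatter) was seen for the same change at the same place, the step for compound 4 is expected to resemble it, so a 2.7-fold higher number from compound 3 to compound 4 (0.42 log units; beyond the scatter) is estimated. Compound 4 is therefore expected near 30000 nM, likely between 15000 nM and 60000 nM.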

Compound 4, half-maximal inhibitory concentration: 27600 nM
For compound 4 the middle estimate is 1.1-fold (0.04 log units) above the measured one; measured number inside the range.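

Swapping the thiourea for the urea that carries the (2-chlorophenyl)carbamoyl group gives a 2.4-fold higher number from compound 3 to compound 4 (0.39 log units; beyond the scatter) in this assay, and this step matches the one seen on the other core: the same change on two cores in this assay, a 2.7-fold higher number (0.43 log units; beyond the scatter) from compound 1 to compound 2 and a 2.4-fold higher number (0.39 log units; beyond the scatter) from compound 3 to compound 4, 1.1-fold (0.04 log units) apart, within the scatter of two such steps. Changing trifluoromethyl to methyl in the urea pair gives a 1.6-fold lower number from compound 2 to compound 4 (0.20 log units; within the scatter), which likewise matches the same change in the thiourea pair: the same change on two cores in this assay, a 1.5-fold lower number (0.16 log units; within the scatter) from compound 1 to compound 3 and a 1.6-fold lower number (0.20 log units; within the scatter) from compound 2 to compound 4, 1.1-fold (0.04 log units) apart, within the scatter of two such steps. The swap therefore carried over at about the same size between these two closely related cores, but two cores cannot show that it would carry over to others, and these numbers do not explain why the urea gives the higher number.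

Going by these compounds, it remains open whether the step would keep its size with an amine or a carboxylic acid in place of the methyl. On these data alone, whether it would hold on other cell lines also remains open.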